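The source may hold more compounds than are shown below. What is called first, only, known or untested is meant among the compounds shown, and "the series" means these compounds.

Within the data shown here, compound 2 `CCCCCCCCN(C)C(=O)Cn1cc(Cc2cnc(=O)n(CC(=O)N3CCNC(=O)C3)c2)c(=O)nc1SCc1ccc(F)cc1` holds the higher of the two numbers so far in a functional assay on a cell-free system (plasma) for inhibition of platelet-activating factor acetylhydrolase (Homo sapiens), tested at 100 nM; a lower number here means less inhibition, a higher number more inhibition at the concentration tested (going by the name of the read-out): compound 2 gives 80%, while compound 1 `CCCCCCCCN(C)C(=O)Cn1cc(Cc2cnc(=O)n(CC)c2)c(=O)nc1SCc1ccc(F)cc1` gives 48%. Among the measured compounds shown here, the single measured step, a number 32 percentage points higher from compound 1 to compound 2 (beyond the scatter), shows that what hangs from the saturated chain carbon bound to the aromatic nitrogen can move the read-out a long way. Compound 3 `CCCCCCCCN(C)C(=O)Cn1cc(Cc2cnc(=O)n(CC(=O)N3CCN(C(C)=O)CC3)c2)c(=O)nc1SCc1ccc(F)cc1` keeps that carbonyl and differs from compound 2 only in the ring on it: 4-acetylpiperazin-1-yl in place of 3-oxopiperazin-1-yl on a carbonyl carbon. For the measured compounds named here, no measured pair shows this sort of exchange of one six-membered ring for another, so the earlier step says only that this part of the molecule is read by this assay, not in which direction such a swap would go. Compound 3 is therefore expected to come out close to its parent, with an expected step of a number 10 percentage points lower from compound 2 to compound 3 (within the scatter) that need not exceed the scatter. The estimate for compound 3 is 70%, between 50% and 88%.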

Compound 3, a percentage reported as inhibition, at one concentration (the size of the read-out at that concentration, not a potency): 80%
The estimate for compound 3 lay 10 percentage points below the measured number; measured number inside the range.
By their numbers in this assay, from the lowest: compound 1; then compounds 2 and 3 (each within the scatter of the next).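

In this assay, the exchange of 3-oxopiperazin-1-yl for 4-acetylpiperazin-1-yl on the carbonyl carbon gives no change at the digits printed from compound 2 to compound 3 (within the scatter), so the gain seen earlier is not tied to the 3-oxopiperazin-1-yl ring, and for this pair the amide hydrogen of that ring is not needed to hold the read-out at this level. The step of a number 32 percentage points higher from compound 1 to compound 3 (beyond the scatter) matches the earlier step of a number 32 percentage points higher from compound 1 to compound 2 (beyond the scatter), so two different ring amides in place of methyl on the saturated chain carbon now show a large rise. Nothing measured on these compounds explains why the two rings read alike.

The compounds shown leave open whether any ring is needed on this carbonyl carbon, as neither a morpholin-4-yl ring nor an open-chain dimethylamino group appears among them. Since the read-out comes from a single concentration, compound 2 and compound 3 could still separate at another concentration.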